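From Methylpiperazine to Piperidine in a Single Step

The source may hold more compounds than are shown below. What is called first, only, known or untested is meant among the compounds shown, and "the series" means these compounds.

Measured so far in a functional assay on MDA-MB-231 cells (Homo sapiens) for inhibition, read by MTT assay, with stated times of 18 h and 4 h; a higher number here means a weaker inhibitor, a lower number a stronger inhibitor
Compound 1 `CCCCCCCCOP(=O)(O)OCCSC(=S)N1CCCCC1` gives 11900 nM
Compound 2 `CCCCCCCCCCOP(=O)(O)OCCSC(=S)N1CCN(C)CC1` gives 29000 nM

Compound 2 has the higher number (29000 nM) and is therefore the weaker inhibitor of the pair, by a gap beyond the usual scatter. Compound 3 `CCCCCCCCCCOP(=O)(O)OCCSC(=S)N1CCCCC1` alters compound 2 in one place (piperidin-1-yl in place of 4-methylpiperazin-1-yl on a thiocarbonyl carbon) on a thiocarbonyl carbon. Compound 1 also carries piperidin-1-yl and gives 11900 nM in this assay, so a moderate fall beyond the scatter is expected. For the measured compounds named here, the expected change (a 2.9-fold lower number from compound 2 to compound 3 (0.46 log units; beyond the scatter)) has no measured step behind it. Compound 3 is estimated at 10000 nM within an expected range of 4000 nM to 22000 nM for now.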

Compound 3, half-maximal inhibitory concentration: 24600 nM
Compound 3: the middle estimate sits 2.5-fold (0.39 log units) below what was measured, outside the stated range (above it).
By their numbers in this assay, from the lowest: compound 1; then compounds 3 and 2 (each within the scatter of the next).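

In this assay, piperidin-1-yl in place of 4-methylpiperazin-1-yl on a thiocarbonyl carbon gives a 1.2-fold lower number from compound 2 to compound 3 (0.07 log units; within the scatter), so this swap does not separate the two compounds. The change that does register lies in the chain: ethyl in place of hydrogen on a saturated chain carbon gives a 2.1-fold higher number from compound 1 to compound 3 (0.32 log units; beyond the scatter), a modest step. Nothing available explains either step. Still open, from the compounds shown here alone, is whether a longer chain would move the number further, and whether a morpholine ring or an open-chain amine on the thiocarbonyl carbon would stay within the scatter.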